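Removing the Phenyl from the Highest Compound

The source may report more compounds than this note shows. Statements on the series, on what has been measured and on what is new or still open speak of the compounds shown alone.

Compounds 1, 2 and 3 have been measured in an assay on cells for inhibition of Voltage-dependent T-type calcium channel subunit alpha-1H (Homo sapiens), read by patch clamp, tested at 10 uM; on this read-out lower numbers stand for less inhibition and higher numbers for more inhibition at the one concentration tested (going by the name of the read-out). Compound 1 `O=C(CC1c2ccccc2N=C(SCCCCCN2CCCC2)N1c1ccc(-c2ccccc2)cc1)NCc1ccc(F)cc1` gives 69%. Compound 2 `O=C(CC1c2ccccc2N=C(SCCCCCN2CCCC2)N1c1ccccc1)NCc1ccc(F)cc1` gives 40%, and compound 3 `CN(C)CCCCCSC1=Nc2ccccc2C(CC(=O)NCc2ccc(F)cc2)N1c1ccc(-c2ccccc2)cc1` gives 83.1%. Compound 3 therefore stands highest of the three: its nearest neighbour is compound 1, and compound 2 lies furthest below it, in both cases beyond the usual scatter of repeated measurements.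

Compound 4 `CN(C)CCCCCSC1=Nc2ccccc2C(CC(=O)NCc2ccc(F)cc2)N1c1ccccc1` has not yet been measured. It differs from compound 3 in one place: hydrogen in place of phenyl on an aromatic carbon. The same change has been seen once before, between compound 1 and compound 2, which share everything else; there it gave a number 29 percentage points lower from compound 1 to compound 2 (beyond the scatter). Among the measured compounds shown here, that is the only measured step that bears on the present one. The other measured step, a number 14.1 percentage points higher from compound 1 to compound 3 (beyond the scatter), concerns a different part of the molecule and only fixes where compound 3 starts from.

A drop of similar size is therefore expected from compound 3 to compound 4, namely a number 29.1 percentage points lower from compound 3 to compound 4 (beyond the scatter). A single earlier example is a thin basis. The range is therefore kept wide. For compound 4 the expected value in this assay is 54%, with a range from 38% to 70%.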

Compound 4, a percentage reported as inhibition, at one concentration (the size of the read-out at that concentration, not a potency): 7%
Beside the measured number, compound 4's estimate is 47 percentage points above it, outside the stated range (below it).
By their numbers in this assay, from the lowest: compound 4; then compound 2; then compound 1; then compound 3.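

In this assay, the change from 4-phenylphenyl to phenyl gives a number 76.1 percentage points lower from compound 3 to compound 4 (beyond the scatter), so the size of this step depends on which amine sits at the end of the chain: the same change on two cores in this assay, a number 29 percentage points lower (beyond the scatter) from compound 1 to compound 2 and a number 76.1 percentage points lower (beyond the scatter) from compound 3 to compound 4, 47.1 percentage points apart, beyond the scatter of two such steps

The amine change shifts as well: with phenyl in place of 4-phenylphenyl, dimethylamino in place of pyrrolidin-1-yl gives a number 33 percentage points lower from compound 2 to compound 4 (beyond the scatter), the opposite direction to the step seen with 4-phenylphenyl: the same change on two cores in this assay, a number 14.1 percentage points higher (beyond the scatter) from compound 1 to compound 3 and a number 33 percentage points lower (beyond the scatter) from compound 2 to compound 4, 47.1 percentage points apart, beyond the scatter of two such steps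

The two changes therefore do not act independently in these four compounds, and a step read on one amine cannot simply be carried over to the other.

On these data alone, whether a methoxy or chloro group in place of that phenyl would behave more like hydrogen or more like phenyl remains open, as does whether a piperidin-1-yl group at the chain end would follow pyrrolidin-1-yl or dimethylamino. These numbers also come from one concentration, so they leave open how the compounds would compare across a range of concentrations, and they do not explain why the two groups depend on each other.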